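A few compounds are considered here, and "the series" means these few. Any claim that something is new, unique, unknown or untested is made for them only; others in the source may bear on it.

Measured compounds:
compound 1 `O=S(=O)(NCCCNCc1cccc2ccccc12)c1cc(C(F)(F)F)cc(C(F)(F)F)c1` — 21000 nM
compound 2 `O=S(=O)(NCCCCNCc1ccc(Br)cc1)c1cc(C(F)(F)F)cc(C(F)(F)F)c1` — 2900 nM
compound 3 `COc1cccc(CNCCCNS(=O)(=O)c2cc(C(F)(F)F)cc(C(F)(F)F)c2)c1` — 3800 nM

In a functional assay on ASPC1 cells (Homo sapiens) for inhibition, read by MTT assay, with a stated time of 72 h (a lower number here means a stronger inhibitor of growth, a higher number a weaker inhibitor of growth), compound 2 gives the lowest of the three numbers, at 2900 nM. Against compound 3 the gap is small and within the scatter, a 1.3-fold higher number from compound 2 to compound 3 (0.12 log units; within the scatter); only compound 1, at 21000 nM, lies clearly apart, and compound 3 sits between them at 3800 nM.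

Compound 4 `O=S(=O)(NCCCNCc1cccc(Cl)c1)c1cc(C(F)(F)F)cc(C(F)(F)F)c1` is not yet measured. It differs from compound 2 by (3-chlorobenzyl)amino in place of ((4-bromobenzyl)amino)methyl on a saturated chain carbon, three bonds along the chain from a sulfonamide nitrogen. For the measured compounds named here, two measured steps bear on this. The step from compound 2 to compound 3 covers the same shortening of the chain together with a change of the benzyl group, and it stayed within the scatter, a 1.3-fold higher number from compound 2 to compound 3 (0.12 log units; within the scatter). The step from compound 1 to compound 3 shows that exchanging the aryl group on that shortened chain can move the number, a 5.5-fold lower number from compound 1 to compound 3 (0.74 log units; beyond the scatter), though that step swaps a larger ring system for a single ring. Compound 4 keeps a single substituted ring like compounds 2 and 3, so no step beyond the scatter is expected in this assay; the expected step is a 1.2-fold higher number from compound 2 to compound 4 (0.08 log units; within the scatter). Compound 4 is therefore estimated at 3500 nM, within 1500 nM to 8000 nM.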

Compound 4, concentration for 50% growth inhibition: 5900 nM
Beside the measured number, compound 4's estimate is 1.7-fold (0.23 log units) below it; the range from low to high includes it.
By their numbers in this assay, from the lowest: compounds 2, 3 and 4 (each within the scatter of the next, the first and the last beyond it); then compound 1.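

In this assay, the exchange at this place now gives a step that just passes the scatter (a 2.0-fold higher number from compound 2 to compound 4 (0.31 log units; beyond the scatter)) and so differs from the within-scatter step to compound 3, although it still changes the chain and the ring together. On the same chain, the ring substituents are not told apart (a 1.6-fold higher number from compound 3 to compound 4 (0.19 log units; within the scatter)), while 3-chlorophenyl in place of naphthalen-1-yl (a 3.6-fold lower number from compound 1 to compound 4 (0.55 log units; beyond the scatter)) gives a second single-ring compound that stands clear of compound 1. No measurement shown gives a cause for these steps.

The share of the chain and that of the ring substituent in the step from compound 2 cannot be separated. Also open, going by these compounds, is how a longer chain, or a nitrile or carboxylic acid on the benzyl ring, would affect the number.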